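Compound 2 to compound 4: a step from a limit

The source may hold more compounds than are shown below. What is called first, only, known or untested is meant among the compounds shown, and "the series" means these compounds.

Notes on the series in a functional assay on SEM cells (Homo sapiens) for cytotoxicity, with a stated time of 72 h; a higher number here means that more compound is needed for the effect, a lower number that less compound is needed. Compound 1 `C=C[C@@](C)(/C=C/c1ccc(O)c(/C=C/C#N)c1)CCC=C(C)C` reads > 36600 nM, which is a limit and not a number. Compound 2 `C=C[C@@](C)(/C=C/c1ccc(O)c(/C=C(\C)C(=O)OCC)c1)CCC=C(C)C` reads > 36600 nM, also a limit. Compound 3 `C=C[C@@](C)(/C=C/c1ccc(O)c(/C=C/c2ccc(Cl)cc2)c1)CCC=C(C)C` reads > 36600 nM, again a limit. The whole set comes down to the limit of > 36600 nM in this assay, at which 3 of the 3 values shown sit. Compound 2 therefore has no number of its own and stands with the other two.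

Compound 4 `CCOC(=O)/C(C)=C/c1cc(/C=C/[C@](C)(/C=C/c2ccc(OC)cc2)CCC=C(C)C)ccc1O` keeps the 2-(ethoxycarbonyl)prop-1-en-1-yl group of compound 2 and differs elsewhere: 2-(4-methoxyphenyl)ethenyl in place of vinyl on a saturated chain carbon bound to a double-bonded chain carbon and two saturated chain carbons. The change lies on a saturated chain carbon bound to a double-bonded chain carbon and two saturated chain carbons.

Three measured steps are at hand: a step that the two limits leave unreadable from compound 1 to compound 2, a step that the two limits leave unreadable from compound 1 to compound 3 and a step that the two limits leave unreadable from compound 2 to compound 3. None of them touches the vinyl group, so they give neither a size nor a direction for this change.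

The expectation rests only on compound 2 with its limit of > 36600 nM, and another reading at a limit is the likeliest outcome. The expected step is a number no higher from compound 2 to compound 4 (the limit leaves the size open), and no step beyond the scatter is expected. For compound 4 the estimated value is 36600 nM, with an expected range of 15000 nM to 70000 nM.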

Compound 4, half-maximal effective concentration: > 36600 nM
Compound 4 was reported as a limit; the forecaster's own chance of this, stated with the estimate: 70%; the middle value lies on the limit itself.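

No new step can be read between compound 2 and compound 4 in this assay, because both are reported only as limits: the limit of > 36600 nM in this assay, at which 4 of the 4 values shown sit.

The compounds shown leave open what concentration any of them needs for the effect in this assay, and whether 2-(4-methoxyphenyl)ethenyl in place of vinyl alters that concentration at all.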